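A few compounds are considered here, and "the series" means these few. Any claim that something is new, unique, unknown or untested is made for them only; others in the source may bear on it.

Measured so far in a physicochemical assay for lipophilicity (a higher number here means a more lipophilic compound, a lower number a more polar compound), are three compounds:

- compound 1 `Fc1ccccc1C1=NC(c2ccccc2)CO1` gives 3.51
- compound 2 `CCSc1ccccc1C1=NC(c2ccccc2)CO1` gives 4.04
- compound 3 `Cc1ccc(C2=NC(c3ccccc3)CO2)cc1` gives 4.11

Compound 2 and compound 3 lie within the usual scatter of each other, while compound 1 sits clearly lower than compound 2. The next structure is compound 4 `FC(F)(F)c1ccccc1C1=NC(c2ccccc2)CO1`, which keeps the shared core of compound 2 and changes one group. It carries trifluoromethyl in place of ethylsulfanyl on an aromatic carbon, ortho to a large group (trifluoromethyl in place of ethylsulfanyl on an aromatic carbon).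

For the measured compounds named here, only one measured step bears on this place. That step is a number 0.53 log units higher from compound 1 to compound 2 (beyond the scatter), with ethylsulfanyl in place of fluoro, and it is modest but beyond the scatter. Going by the values given here, no measured compound yet carries trifluoromethyl, so the size of this swap has to be judged indirectly. Compound 1 at 3.51 and compound 2 at 4.04 frame the expectation, and compound 4 is expected to fall between them, nearer the upper one. A small downward move in this assay is therefore expected, smaller than the measured step and perhaps no larger than the scatter. The expected change is a number 0.14 log units lower from compound 2 to compound 4 (within the scatter) in this estimate. For compound 4 the estimated value is 3.9, with an expected range from 3.55 to 4.25.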

Compound 4, partition coefficient: 3.71
The estimate for compound 4 lay 0.19 log units above the measured number; measured number inside the range.
By their numbers in this assay, from the lowest: compounds 1 and 4 (each within the scatter of the next); then compounds 2 and 3 (each within the scatter of the next).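

In this assay, the swap on this aromatic carbon, ortho to a large group, gives a number 0.33 log units lower from compound 2 to compound 4 (beyond the scatter) and so separates trifluoromethyl from ethylsulfanyl at this place, even though trifluoromethyl has the larger count of heavy atoms. The comparison with the smaller fluoro group gives a number 0.20 log units higher from compound 1 to compound 4 (within the scatter) and so leaves trifluoromethyl and fluoro indistinguishable here, while ethylsulfanyl in compound 2 now stands clearly apart from both. Nothing available explains why these groups fall in this arrangement.

From the compounds shown here alone, the reading at this place rests on just three groups on a single shared core, so it remains open whether the same arrangement would hold if the phenyl group on the core were changed. Going by these compounds, it is also open where an amine, a carboxylic acid or a longer chain such as butylsulfanyl would fall relative to these three groups in this assay at this same aromatic carbon.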